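From a Ring Hydrogen to a Piperidinylmethyl Group

The compounds below may be only part of what the source reports. "The series", "measured", "known", "first", "only" and "open" are said of these compounds alone.

Of the compounds shown here, three built on a shared core have been tested in a functional assay on the whole organism (strain Wistar albino) for inhibition, with Rattus norvegicus as the target, read by paw edema, with a stated time of 1 h, at a dose of 25 mg/kg by the oral route; a higher number here means more inhibition at the dose given (going by the name of the read-out), a lower number less inhibition. In this assay compound 1 `O=c1[nH]nc(-c2csc(-c3ccccc3)n2)o1` gives 34.8%. Compound 2 `Nc1cc(-c2ccccc2)nn1C(=O)c1csc(-c2ccccc2)n1` gives 42.1% in this assay. Compound 3 `S=c1[nH]nc(-c2csc(-c3ccccc3)n2)o1` gives 37.9% in this assay. Compound 3 sits in the middle of the three numbers; compound 1 and compound 2 both lie within the usual scatter of it, so the three are not told apart by this assay.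

Compound 4 `S=c1oc(-c2csc(-c3ccccc3)n2)nn1CN1CCCCC1` has not yet been measured. It differs from compound 3 in one place: (piperidin-1-yl)methyl in place of hydrogen on an aromatic nitrogen. For the measured compounds named here, no pair of measured compounds shows what this kind of change does in this assay, so there is nothing in the numbers to point in either direction. The account therefore expects the step of a number 2.1 percentage points higher from compound 3 to compound 4 (within the scatter) to stay within the scatter, with no clear change in either direction. Compound 4 is expected to give about 40% in this assay, within a range from 25% to 55%.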

Compound 4, a percentage reported as inhibition, in the whole organism at one dose (the size of the read-out at that dose, not a potency): 44.8%
Compound 4: the middle estimate sits 4.8 percentage points below what was measured; the measured number falls inside the stated range.
By their numbers in this assay, from the lowest: compounds 1, 3, 2 and 4 (each within the scatter of the next).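

The hydrogen on the aromatic nitrogen of compound 3 can give way to (piperidin-1-yl)methyl, a group carrying a six-membered non-aromatic ring, without a clear change in this assay: the replacement gives a number 6.9 percentage points higher from compound 3 to compound 4 (within the scatter). For the compounds shown here, this is the first view of this position, and it shows that the response at the dose given holds with this much larger group in place of hydrogen, with neither a clear gain nor a clear loss. No measurement at hand bears on what lies behind this result.

As far as these compounds go, whether a plain methyl or a morpholin-4-ylmethyl group on the same nitrogen would give a step beyond the scatter remains open. So does whether (piperidin-1-yl)methyl would behave the same way on compound 1, which carries a carbonyl where compound 3 carries a thiocarbonyl.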